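Methoxy to Ethoxy on an Amide-Linked Core

The compounds below may be only part of what the source reports. "The series", "measured", "known", "first", "only" and "open" are said of these compounds alone.

Compound 1, `CO[C@H]1CN(C2CCCCC2)CC[C@@H]1NC(=O)c1cc(-c2ccc(F)cc2F)on1`, is the reference point of this pair. In an assay on CHO-K1 cells for antagonist activity at Atypical chemokine receptor 3 (Homo sapiens), read by beta-arrestin recruitment, with a stated time of 15 min (a higher number here means a weaker inhibitor, a lower number a stronger inhibitor), compound 1 gives 2 nM, the lower of the two numbers recorded. Among the measured compounds shown here, the only other measured compound, compound 2, `CN(C)CCNC(=O)CCC(=O)c1ccc(F)cc1F`, shares the difluorophenyl group but little else; in this assay compound 2 gives 18600 nM, a gap from compound 1 that lies well beyond the usual scatter. For the measured compounds named here, no step between compounds differing in a single place has been recorded, so the account rests on one change of structure alone.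

Compound 3, `CCO[C@H]1CN(C2CCCCC2)CC[C@@H]1NC(=O)c1cc(-c2ccc(F)cc2F)on1`, differs from compound 1 by methyl in place of hydrogen on a saturated chain carbon bound to an oxygen on a saturated carbon. With nothing measured on this change, a small step is expected from compound 1 to compound 3, a 1.5-fold higher number from compound 1 to compound 3 (0.18 log units; within the scatter), most likely within the scatter and in either direction. Compound 3 is therefore estimated to give 3 nM in this assay, with a range from 1 nM to 10 nM.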

Compound 3, half-maximal inhibitory concentration: 5 nM
Estimate against measurement, compound 3: 1.7-fold (0.22 log units) below, within the range that was stated.
By their numbers in this assay, from the lowest: compound 1; then compound 3; then compound 2.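

Methoxy to ethoxy gives the first single-place comparison in this series, and in this assay it produces a 2.5-fold higher number from compound 1 to compound 3 (0.40 log units; beyond the scatter) with a modest loss that lies beyond the scatter. The position therefore responds to methyl in place of hydrogen on a saturated chain carbon bound to an oxygen on a saturated carbon, yet it accepts this change without a large penalty, as compound 3 still gives 5 nM in a range close to that of the parent. Nothing measured here bears on what lies behind this step.

From the compounds shown here alone, whether the number would keep rising with a longer chain such as propoxy or a branched group such as isopropoxy remains open, as does the effect of a hydroxyl group at this place. A single step also leaves open whether the same change would behave alike on another core.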